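Methyl added on the fluorophenyl amide of compound 1

The source may report more compounds than this note shows. Statements on the series, on what has been measured and on what is new or still open speak of the compounds shown alone.

Compound 1 `O=C(CN1CCN(c2nnc(Cc3ccncc3)c3ccccc23)CC1)Nc1cccc(F)c1` stands lowest of the three numbers in a functional assay on A549 cells (Homo sapiens) for cytotoxicity, read by MTT assay, with a stated time of 72 h; on this read-out higher numbers stand for weaker inhibition and lower numbers for stronger inhibition: compound 1 gives 4600 nM. Compound 2 `O=C(CN1CCN(c2nnc(Cc3ccccc3)c3ccccc23)CC1)Nc1ccc(F)c(F)c1` gives 10100 nM, and compound 3 `O=C(CN1CCN(c2nnc(Cc3ccccc3)c3ccccc23)CC1)Nc1cccc(F)c1` gives 130000 nM. Both single-site steps run to compound 3: a 28-fold higher number from compound 1 to compound 3 (1.45 log units; beyond the scatter), and a 13-fold higher number from compound 2 to compound 3 (1.11 log units; beyond the scatter).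

Compound 4 `Cc1ccc(F)cc1NC(=O)CN1CCN(c2nnc(Cc3ccncc3)c3ccccc23)CC1` differs from compound 1 in one place: methyl in place of hydrogen on an aromatic carbon. For the measured compounds named here, no measured step in this set adds a methyl anywhere, so none bears directly on this change. Going by the values given here, the only step on the 3-fluorophenyl part, a 13-fold higher number from compound 2 to compound 3 (1.11 log units; beyond the scatter), concerns fluoro rather than methyl, and shows only that a small change there can move the number far. Without a direct precedent, the expectation for compound 4 in this assay is a modest step, direction open, and a wide range is kept.

Compound 4 is expected to give 3500 nM in this assay, with a lower end of 900 nM and an upper end of 14000 nM. This estimate corresponds to an expected step of a 1.3-fold lower number from compound 1 to compound 4 (0.12 log units; within the scatter).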

Compound 4, half-maximal inhibitory concentration: 38900 nM
For compound 4 the middle estimate is 11-fold (1.05 log units) below the measured one; the whole stated range lies below it.
By their numbers in this assay, from the lowest: compound 1; then compound 2; then compound 4; then compound 3.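

Working notes on the amide ring: the aromatic carbon ortho to a large group and para to the fluoro group is not neutral in this assay. A single added methyl, one heavy atom, gives an 8.5-fold higher number from compound 1 to compound 4 (0.93 log units; beyond the scatter), so the change from 3-fluorophenyl to 5-fluoro-2-methylphenyl moves the number in the weaker direction. For the compounds shown here, the earlier step on this ring, a 13-fold higher number from compound 2 to compound 3 (1.11 log units; beyond the scatter), concerned fluoro and compounds carrying phenyl rather than pyridin-4-yl, so this is the first sign that methyl on this ring, with pyridin-4-yl in place, also moves the number beyond the scatter. Nothing measured here explains the step.

From the compounds shown here alone, it remains open whether a chloro or methoxy group on the same carbon would behave like methyl. Also open, going by these compounds, is whether methyl gives a similar step in a compound carrying phenyl in place of pyridin-4-yl.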